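A few compounds are considered here, and "the series" means these few. Any claim that something is new, unique, unknown or untested is made for them only; others in the source may bear on it.

Working notes on the series. Two compounds share a core and differ at a single aromatic carbon. Compound 1 `COc1ccc(/C=C/c2cc(OC)cc(OC)c2-c2oc3ccc(OC)cc3c(=O)c2O)cc1` gives 1780 nM in a functional assay on RAW264.7 cells (Mus musculus), read by Griess assay, with stated times of 1 h and 24 h; a lower number here means a stronger inhibitor, a higher number a weaker inhibitor. Compound 2 `COc1ccc(/C=C/c2cc(OC)cc(OC)c2-c2oc3ccc(F)cc3c(=O)c2O)cc1` gives 1350 nM in this assay. Going by the values given here, the only measured step so far is a 1.3-fold lower number from compound 1 to compound 2 (0.12 log units; within the scatter). On the two numbers available, compound 2 holds the lower one, with compound 1 as its nearest neighbour, and the gap between them stays within the scatter, so no ranking of the two is claimed.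

Compound 3 `COc1ccc(/C=C/c2cc(OC)cc(OC)c2-c2oc3ccc(Cl)cc3c(=O)c2O)cc1` is not yet measured. It differs from compound 2 by chloro in place of fluoro on an aromatic carbon. Among the compounds with values here, the one measured step that bears on this position is a 1.3-fold lower number from compound 1 to compound 2 (0.12 log units; within the scatter), which stayed within the scatter. Nothing measured separates chloro from fluoro at this carbon. The expected step in this assay from compound 2 to compound 3 is therefore of no size beyond the scatter, in either direction. The estimate for compound 3 in this assay is 1200 nM, with a range from 600 nM to 2500 nM. This corresponds to an expected step of a 1.1-fold lower number from compound 2 to compound 3 (0.05 log units; within the scatter).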

Compound 3, half-maximal inhibitory concentration: 4830 nM
Estimate against measurement, compound 3: 4.0-fold (0.60 log units) below; measured number outside the range, above it.
By their numbers in this assay, from the lowest: compounds 2 and 1 (each within the scatter of the next); then compound 3.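

The position is not indifferent to its substituent, as the earlier pair could not show: in this assay the change of fluoro to chloro gives a 3.6-fold higher number from compound 2 to compound 3 (0.55 log units; beyond the scatter) and the change of methoxy to chloro gives a 2.7-fold higher number from compound 1 to compound 3 (0.43 log units; beyond the scatter), while methoxy and fluoro themselves stay within the scatter of each other. Compound 3 therefore stands apart as the weakest of the three inhibitors, and fluoro and chloro, each a single heavy atom on the same aromatic carbon, cannot be treated as interchangeable here. No measurement on hand explains why chloro separates from the other two groups at this carbon.

The compounds shown leave open whether the higher number is particular to chloro or would also appear with bromo, trifluoromethyl or an amine at this carbon, and how the unsubstituted carbon compares with all three. They also leave open whether chloro in place of fluoro on another aromatic carbon of the shared core would give a step of similar size in this assay or none beyond the scatter.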